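Sulfonyl substituent exchange in a chloroaryl alkyne acid series

This account rests on a few compounds, and the source may have more. Where it says the series, first, only, none or still open, it means among the compounds named here.

Three compounds have numbers in an assay on CHO cells for displacement of a labelled ligand from prostaglandin D2 receptor 2 (Homo sapiens), read by scintillation counting; a higher number here means a weaker inhibitor, a lower number a stronger inhibitor. Compound 1 `COC1c2ccc(C#Cc3cc(Cl)ccc3OCC(=O)O)cc2S(=O)(=O)C1(C)C` gives 21 nM in this assay. Compound 3 `O=C(O)COc1ccc(Cl)cc1C#Cc1ccccc1Cl` gives 28 nM. Compound 2 `Cc1ccc(S(=O)(=O)NC(C)C)cc1C#Cc1cc(Cl)ccc1OCC(=O)O` gives 3.4 nM, the lowest of the three; its nearest neighbour is compound 1 and its furthest is compound 3, and both gaps lie beyond the usual scatter, so compound 2 is the strongest inhibitor among the measured set.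

Compound 4 `Cc1ccc(S(C)(=O)=O)cc1C#Cc1cc(Cl)ccc1OCC(=O)O` has not been measured. It differs from compound 2 in one place: methyl in place of isopropylamino on a sulfonyl sulfur. Within the data shown here, no pair of measured compounds differing in a single place is available, so the size of this kind of step cannot be read from the series itself. The sulfonyl group is retained, and the expectation is a small move toward a higher inhibition constant, possibly not beyond the scatter. Compound 4 is therefore estimated at 8 nM, with a range from 2.5 nM to 25 nM. The step of a 2.4-fold higher number from compound 2 to compound 4 (0.37 log units; beyond the scatter) is expected to stay modest.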

Compound 4, inhibition constant: 5 nM
The estimate for compound 4 lay 1.6-fold (0.20 log units) above the measured number; low and high end bracket the measured number.
By their numbers in this assay, from the lowest: compounds 2 and 4 (each within the scatter of the next); then compounds 1 and 3 (each within the scatter of the next).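

In this assay, the series now has its first step in a single place: a 1.5-fold higher number from compound 2 to compound 4 (0.17 log units; within the scatter). At this position on the sulfonyl sulfur, isopropylamino and its hydrogen-bond donor can therefore give way to methyl without a shift beyond the scatter, so neither the nitrogen nor the isopropyl carbons are required to keep the number in this range. Nothing available bears on the reason for this tolerance.

As far as these compounds go, what a carbonyl in place of the sulfonyl group would do remains open, as does the effect of a longer chain such as n-butyl or a morpholine ring on the sulfur. From the compounds shown here alone, it is also open whether an unsubstituted amino group on the sulfur would stay within the scatter of compound 2 and compound 4.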